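Indole acrylic acids: N-substitution and cytotoxicity on KB cells

This account rests on a few compounds, and the source may have more. Where it says the series, first, only, none or still open, it means among the compounds named here.

Measured compounds:
compound 1 `CC(=O)n1cc(/C=C(/C(=O)O)c2ccc(Cl)cc2)c2cc(OCc3ccccc3)ccc21`: > 100000 nM
compound 2 `O=C(O)/C(=C/c1c[nH]c2ccc(OCc3ccccc3)cc12)c1ccccc1`: 55500 nM
compound 3 `COc1ccc(/C(=C\c2c[nH]c3ccc(OCc4ccccc4)cc23)C(=O)O)cc1`: 38500 nM

In a functional assay on KB cells (Homo sapiens) for cytotoxicity, read by MTT assay, with a stated time of 72 h (a lower number here means a stronger inhibitor, a higher number a weaker inhibitor), compound 2 stands highest of the two numbers shown, with compound 3 nearest; the step of a 1.4-fold lower number from compound 2 to compound 3 (0.16 log units; within the scatter) is within the scatter, so no order between them is claimed. The value of compound 1 in this assay is a limit of the assay, not a number (the limit of > 100000 nM in this assay, at which 1 of the 3 values shown sits). For the measured compounds named here, compound 1 differs from compound 2 in more than one place, so no single step joins them; their two values only show that compound 1 gave no number at all while compound 2 did.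

Compound 4 `COc1ccc(Cn2cc(/C=C(/C(=O)O)c3ccccc3)c3cc(OCc4ccccc4)ccc32)cc1` differs from compound 2 by 4-methoxybenzyl in place of hydrogen on an aromatic nitrogen. Going by the values given here, no measured step touches the aromatic nitrogen, so the step of a 1.4-fold lower number from compound 2 to compound 3 (0.16 log units; within the scatter) is the only one, and it bears on another position. With nothing pointing either way, the step of a 1.1-fold higher number from compound 2 to compound 4 (0.03 log units; within the scatter) is expected to fall within the scatter, with wide uncertainty. Compound 4 is therefore estimated at 60000 nM in this assay, in the range 20000 nM to 180000 nM.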

Compound 4, half-maximal inhibitory concentration: 97000 nM
Beside the measured number, compound 4's estimate is 1.6-fold (0.21 log units) below it, within the range that was stated.
By their numbers in this assay, from the lowest: compounds 3, 2 and 4 (each within the scatter of the next, the first and the last beyond it). At a limit, above all of these: compound 1.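

The aromatic nitrogen now has its first single-place step in this assay: a 1.7-fold higher number from compound 2 to compound 4 (0.24 log units; within the scatter). Compound 4 still gives a number with 4-methoxybenzyl in place of hydrogen, so the hydrogen on this nitrogen is not required for a value in this range. Nothing measured here gives a cause for this step.

For the compounds shown here, it stays open whether other groups on this nitrogen, such as methyl, a longer alkyl chain or a chain ending in an amine, also stay within the scatter of compound 2, and compound 1, with acetyl on this nitrogen, differs from compound 2 in more than one place and gives no step. Also open, going by these compounds, is what an amide in place of the carboxylic acid would do.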